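This account rests on a few compounds, and the source may have more. Where it says the series, first, only, none or still open, it means among the compounds named here.

Two members of the series have numbers in an assay on HEK-293T cells for inhibition of Bile acid receptor (Homo sapiens), read by a beta-lactamase reporter, with a stated time of 16 h (a higher number here means a weaker inhibitor, a lower number a stronger inhibitor), so far. Compound 1 `O=C(Nc1ccc(F)c(S(=O)(=O)N2CCOCC2)c1)c1cnn(-c2ccccc2)c1` gives 9400 nM in this assay. Compound 2 `Cc1ccc(-c2nn(C(C)C)cc2C(=O)Nc2ccc(C)c(S(=O)(=O)N3CCOCC3)c2)cc1`, which carries a 4-methylphenyl group and an isopropyl on the ring nitrogen of its five-membered aromatic ring, gives 1690 nM in this assay. Compound 2 thus stands at the lower of the two numbers, and the gap to compound 1 lies beyond the usual scatter; the two structures differ in several places at once, so no single step can be read from them.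

Compound 3 `Cc1ccc(-c2nn(CCCCO)cc2C(=O)Nc2ccc(C)c(S(=O)(=O)N3CCOCC3)c2)cc1` is the next compound, not yet measured in this assay. Relative to compound 2 the change is 4-hydroxybutyl in place of isopropyl on an aromatic nitrogen, a 4-hydroxybutyl in place of isopropyl on an aromatic nitrogen. For the measured compounds named here, no measured pair isolates this kind of change, so there is nothing to anchor the size of the step; the expectation is a small shift, at most a modest weakening, and possibly none beyond the scatter, given as a 1.8-fold higher number from compound 2 to compound 3 (0.25 log units; within the scatter). The estimate for compound 3 in this assay is 3000 nM, with a range from 1000 nM to 9000 nM.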

Compound 3, half-maximal inhibitory concentration: 2610 nM
The estimate for compound 3 lay 1.1-fold (0.06 log units) above the measured number; the measured number falls inside the stated range.
By their numbers in this assay, from the lowest: compounds 2 and 3 (each within the scatter of the next); then compound 1.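

For the compounds shown here, the step at the aromatic nitrogen is the first that changes one place only: with 4-hydroxybutyl in place of isopropyl, this assay gives a 1.5-fold higher number from compound 2 to compound 3 (0.19 log units; within the scatter). At this position, two ring bonds from the ring atom that bears the 4-methylphenyl group, the isopropyl can thus give way to a chain with more heavy atoms, a hydrogen-bond donor and a hydrogen-bond acceptor, with no difference beyond the scatter. Nothing measured on these compounds speaks to a reason for this result.

As far as these compounds go, it remains open how far this tolerance extends, as a longer chain, a terminal amine or a carboxylic acid on the chain at this nitrogen could read differently from the 4-hydroxybutyl group. The gap between compound 1 and the other two compounds also stays unassigned: compound 1 differs from each of them in several places at once, and the share of the 4-methylphenyl group in that gap cannot be read.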